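The source may hold more compounds than are shown below. What is called first, only, known or untested is meant among the compounds shown, and "the series" means these compounds.

Compound 1 `NC(=S)N1CCc2c(OCCCCCOc3ccc(Cl)cc3)cccc21`: > 50000 nM
Compound 2 `O=C(NC(=S)N1CCc2c(OCCCCCOc3ccc(Cl)cc3)cccc21)c1cccs1`: 10700 nM
Compound 3 `O=C(NC(=S)N1CCc2c(OCCCCCOc3ccc(Cl)cc3)cccc21)c1ccsc1`: > 50000 nM

In an ADME assay on Huh-7 cells (Homo sapiens) for cytotoxicity (a higher number here means that more compound is tolerated, a lower number that less compound is tolerated), compound 1 gives only a limit, > 50000 nM. Compound 2 gives 10700 nM in this assay, which is an at least 4.6-fold lower number from compound 1 to compound 2 (0.66 log units; beyond the scatter). Compound 3 again gives only a limit, > 50000 nM. Compound 3 thus sits at the limit of > 50000 nM in this assay, at which 2 of the 3 values shown sit, and the step of an at least 4.6-fold higher number from compound 2 to compound 3 (0.66 log units; beyond the scatter) is read against that limit, while a step that the two limits leave unreadable from compound 1 to compound 3. Compound 4 `O=C(NC(=S)N1CCc2c(OCCCCCOc3ccc(Cl)cc3)cccc21)c1ccno1` differs from compound 3 in one place: 1,2-oxazol-5-yl in place of thiophen-3-yl on a carbonyl carbon. Among the compounds with values here, no measured step exchanges this carbonyl substituent for a ring with two hetero atoms; the only step at that position, an at least 4.6-fold higher number from compound 2 to compound 3 (0.66 log units; beyond the scatter), ran from a number up to the limit. Compound 4 is therefore expected to remain near that limit, with a number no higher from compound 3 to compound 4 (the limit leaves the size open) as the estimated step. The estimate for compound 4 is 50000 nM, ranging from 12000 nM to 150000 nM.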

Compound 4, half-maximal cytotoxic concentration: 37100 nM
For compound 4 the middle estimate is 1.3-fold (0.13 log units) above the measured one; the measured number falls inside the stated range.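

In this assay the carbonyl carbon now carries a ring with two hetero atoms, and 1,2-oxazol-5-yl gives a 3.5-fold higher number from compound 2 to compound 4 (0.54 log units; beyond the scatter) in place of thiophen-2-yl, so thiophen-3-yl is no longer the only ring with a higher number there. The other two steps give an at least 1.3-fold lower number from compound 3 to compound 4 (0.12 log units; that floor lies within the scatter) and an at least 1.3-fold lower number from compound 1 to compound 4 (0.12 log units; that floor lies within the scatter) as floors only, with no size fixed. Both rest on a limit: the limit of > 50000 nM in this assay, at which 2 of the 4 values shown sit. On these data alone, whether thiophen-2-yl alone lowers the number remains open, as do phenyl, pyridin-3-yl or acetyl on this carbonyl carbon.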